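The source may hold more compounds than are shown below. What is called first, only, known or untested is meant among the compounds shown, and "the series" means these compounds.

Measured so far in a functional assay on the whole organism for inhibition, with Rattus norvegicus as the target, read by paw edema, with stated times of 1 h and 3 h, at a dose of 50 mg/kg by the oral route; on this read-out lower numbers stand for less inhibition and higher numbers for more inhibition at the one dose given (going by the name of the read-out):
compound 1 `C/C(=N\OCC(=O)O)c1ccccc1O` — < 20%, a limit of this assay
compound 2 `C/C(=N\OCC(=O)O)c1ccc(C(C)(C)C)cc1` — < 20%, a limit of this assay

Compound 2 stands at the limit of this assay: its value is not a number but a limit. For the measured compounds named here, compound 1 sits there as well, and the limit of < 20% in this assay, at which 2 of the 2 values shown sit, is the whole of the evidence this pair offers; no step between measured compounds can be read from two limits. Compound 3 `COc1ccc(/C(C)=N/OCC(=O)O)cc1` is the next member. From compound 2 it differs by methoxy in place of tert-butyl on an aromatic carbon. With both shown values at a limit, nothing in the series points to a step beyond the usual scatter in either direction, and none is expected. The step that the limit leaves unreadable from compound 2 to compound 3 is expected to be small, if any. Compound 3 is accordingly estimated at 12%, with a range of 0% to 30%, and is likely to come back once more as a limit.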

Compound 3, a percentage reported as inhibition, in the whole organism at one dose (the size of the read-out at that dose, not a potency): < 20%
Compound 3: only a limit was reported (the forecaster's own chance of this, stated with the estimate: 70%); the middle value lies beyond the limit too.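

No step can be read from compound 2 to compound 3 in this assay, since both results are limits and not numbers: the limit of < 20% in this assay, at which 3 of the 3 values shown sit. The compounds shown leave open whether any group on the shared core gives a readable inhibition at this dose, and how the three compare.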